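The compounds below may be only part of what the source reports. "The series", "measured", "known", "first", "only" and "open" are said of these compounds alone.

Of the compounds shown here, two built on the same core have been measured in an assay on isolated protein for inhibition of protein kinase C zeta type (Homo sapiens), with stated times of 1 h and 2.5 min, tested at 30 uM; a lower number here means less inhibition, a higher number more inhibition at the concentration tested (going by the name of the read-out). Compound 1 `COCCOC(=O)c1c(-c2ccc(OC)c(OC)c2)csc1N` gives 57%. Compound 2 `COc1ccc(-c2csc(N)c2C(=O)OCc2ccncc2)cc1OC` gives 53%, which is the lower of the two numbers, although the step of a number 4 percentage points lower from compound 1 to compound 2 (within the scatter) lies within the scatter, so the two compounds are not distinguished by this assay. Compound 3 `COc1ccc(-c2csc(N)c2C(=O)NCc2ccncc2)cc1OC` has not yet been measured in this assay. It differs from compound 2 in one place: ((pyridin-4-yl)methyl)amino in place of (pyridin-4-yl)methoxy on a carbonyl carbon. Among the compounds with values here, no measured step touches the link between the carbonyl carbon and the pyridin-4-yl-bearing group; the only step known exchanges the group on the other side of that link and was small. With no evidence pointing either way, the step of no change at the digits printed from compound 2 to compound 3 (within the scatter) is expected to stay within the scatter. Compound 3 is therefore estimated at 53%, in a range from 33% to 73%.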

Compound 3, a percentage reported as inhibition, at one concentration (the size of the read-out at that concentration, not a potency): 3%
The estimate for compound 3 lay 50 percentage points above the measured number, and the stated range ends above it.
By their numbers in this assay, from the lowest: compound 3; then compounds 2 and 1 (each within the scatter of the next).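

In this assay the atom that links the group to the carbonyl carbon proves decisive: ((pyridin-4-yl)methyl)amino in place of (pyridin-4-yl)methoxy brings a number 50 percentage points lower from compound 2 to compound 3 (beyond the scatter) even though both groups hold the same kind of aromatic ring and the same number of heavy atoms. Replacing 2-methoxyethoxy with ((pyridin-4-yl)methyl)amino brings a number 54 percentage points lower from compound 1 to compound 3 (beyond the scatter) and so the large step appears from both oxygen-linked compounds. The earlier pair, both linked through oxygen, had shown only that the group on that oxygen could vary without a difference beyond the scatter. Nothing available explains why exchanging the linking oxygen for a nitrogen carrying a hydrogen has so large an effect. Going by these compounds, whether inhibition stays this low with other groups on the carbonyl carbon, such as methylamino, 2-methoxyethylamino or a dimethylamino group, remains open.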